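Ring amine change from compound 1 to compound 3

The source may hold more compounds than are shown below. What is called first, only, known or untested is meant among the compounds shown, and "the series" means these compounds.

Measured so far:
compound 1, `COc1cc2c(Oc3ccc(NC(=O)c4cc(-c5ccccc5F)ccn4)cc3F)ccnc2cc1OCCCN1CCN(C)CC1`: 220 nM
compound 2, `COc1cc2c(Oc3ccc(NC(=O)c4cc(-c5ccc(C(F)(F)F)cc5)ccn4)cc3F)ccnc2cc1OCCCN1CCN(C)CC1`: 200 nM

Among the measured compounds shown here, in a functional assay on HT-29 cells (Homo sapiens) for cytotoxicity, read by MTT assay, with a stated time of 72 h (a lower number here means a stronger inhibitor, a higher number a weaker inhibitor), compound 1 gives 220 nM, the highest of the two numbers so far; its nearest neighbour is compound 2, and the step of a 1.1-fold lower number from compound 1 to compound 2 (0.04 log units; within the scatter) lies within the scatter, so the two compounds cannot be ordered.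

Compound 3, `COc1cc2c(Oc3ccc(NC(=O)c4cc(-c5ccccc5F)ccn4)cc3F)ccnc2cc1OCCCN1CCCC1`, has not been measured in this assay. It differs from compound 1 only at the end of the chain: pyrrolidin-1-yl in place of 4-methylpiperazin-1-yl on a saturated chain carbon, three bonds along the chain from an oxygen on an aromatic ring. For the measured compounds named here, the one measured step, from compound 1 to compound 2, concerns the aryl group on the other side of the molecule and so does not bear on this change; no measured pair informs the amine ring swap.

Going by the values given here, with no comparable step, the expectation for compound 3 is a number close to that of compound 1, a 1.1-fold higher number from compound 1 to compound 3 (0.06 log units; within the scatter), with no step beyond the scatter foreseen in either direction. Compound 3 is therefore estimated at 250 nM in this assay, within a range from 100 nM to 650 nM.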

Compound 3, half-maximal inhibitory concentration: 230 nM
Estimate against measurement, compound 3: 1.1-fold (0.04 log units) above; measured number inside the range.
By their numbers in this assay, from the lowest: compounds 2, 1 and 3 (each within the scatter of the next).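

In this assay, the amine ring at the end of the chain can change with no readable effect on the number: a 1.0-fold higher number from compound 1 to compound 3 (0.02 log units; within the scatter), for pyrrolidin-1-yl in place of 4-methylpiperazin-1-yl. Among the compounds shown here, this is the first reading at this position, on a saturated chain carbon, three bonds along the chain from an oxygen on an aromatic ring, and it shows that a smaller ring with one nitrogen instead of two leaves compound 3 indistinguishable from compound 1. No supporting data bear on this result.

From the compounds shown here alone, it remains open whether the same swap reads alike with 4-(trifluoromethyl)phenyl in place of 2-fluorophenyl. Also open, going by these compounds, is whether a morpholine ring, a primary amine or a carboxylic acid at the chain end, or a longer chain, would move the number beyond the scatter.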